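The source may hold more compounds than are shown below. What is called first, only, known or untested is meant among the compounds shown, and "the series" means these compounds.

Measured compounds in a physicochemical assay for solubility, at pH 7; a lower number here means a less soluble compound, a higher number a more soluble compound:
compound 1 `CN1CCC(C(=O)N2Cc3c(NC(=O)c4ccc(Cl)cc4)n[nH]c3C2(C)C)CC1`, recorded only as a limit of the assay, > 225000 nM.
compound 2 `CN1CCC(C(=O)N2Cc3c(NC(=O)c4ccc(F)c(F)c4)n[nH]c3C2(C)C)CC1`, likewise recorded only as a limit, > 225000 nM.
compound 3 `CN1CCC(C(=O)N2Cc3c(NC(=O)c4ccc(C(F)(F)F)cc4)n[nH]c3C2(C)C)CC1`, the one numerical value, 191000 nM.

Among the measured compounds shown here, compound 3 therefore stands as the only read number in this assay; the other two members sit at the limit of > 225000 nM in this assay, at which 2 of the 3 values shown sit. The steps towards compound 3 are small: an at least 1.1-fold lower number from compound 1 to compound 3 (0.07 log units; that floor lies within the scatter) and an at least 1.1-fold lower number from compound 2 to compound 3 (0.07 log units; that floor lies within the scatter), both floors within the scatter. The step that the two limits leave unreadable from compound 1 to compound 2 cannot be read because both ends are limits.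

The next compound, compound 4 `CN1CCC(C(=O)N2Cc3c(NC(=O)NCc4ccccc4)n[nH]c3C2(C)C)CC1`, differs from compound 3 in one place: benzylamino in place of 4-(trifluoromethyl)phenyl on a carbonyl carbon. For the measured compounds named here, no measured step exchanges an aryl group for a benzylamino group on the carbonyl carbon, so the two small steps towards compound 3 are the only guide, and they say that changes on the aryl part moved solubility little. With compound 3 already close to the limit, the expectation for compound 4 is a small rise, likely ending at the limit again: a 1.1-fold higher number from compound 3 to compound 4 (0.05 log units; within the scatter) is the step expected. The estimate for compound 4 in this assay is 215000 nM, with a range from 110000 nM to 225000 nM.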

Compound 4, solubility: > 225000 nM
Compound 4: only a limit was reported; the forecaster's own chance of this, stated with the estimate: 55%; middle value at least 1.0-fold (0.01 log units) away from the limit.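

Benzylamino in place of 4-(trifluoromethyl)phenyl on a carbonyl carbon brings a nitrogen and a hydrogen-bond donor to this position, the first change here that does not leave an aryl ring as the group entering, and it gives an at least 1.1-fold higher number from compound 3 to compound 4 (0.07 log units; that floor lies within the scatter) in this assay. Compound 4 is recorded only as a limit of the assay, > 225000 nM. The steps to compound 4 from compound 1 and from compound 2 cannot be read, and the series now rests mostly on one limit: the limit of > 225000 nM in this assay, at which 3 of the 4 values shown sit.

The compounds shown leave open whether any group on this carbonyl carbon gives a step beyond the scatter in this assay, as compound 3 holds the only read number and its readable steps are floors within the scatter. Also open, going by these compounds, is how a longer alkyl chain, a carboxylic acid or a tertiary amine on this carbonyl carbon would read, and whether changes elsewhere on the shared core would bring the values off the limit.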